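The compounds below may be only part of what the source reports. "The series", "measured", "known", "first", "only" and "open" are said of these compounds alone.

In a functional assay on SF-539 cells (Homo sapiens) for cytotoxicity, read by sulforhodamine B assay, with a stated time of 48 h (a higher number here means that more compound is tolerated, a lower number that less compound is tolerated), compound 1 `ClCc1ccccc1Cn1cnc2c(Cl)nc(Cl)nc21` gives 5620 nM. Compound 2 `ClCc1ccccc1Cn1cnc2c(Cl)ncnc21` gives 55000 nM in this assay, and compound 3 `ClCc1cccc(Cn2cnc3c(Cl)ncnc32)c1` gives 61700 nM. Compound 2 and compound 3 are built from the same atoms joined differently; the difference between the two cores is not broken down here, and their two values lie within the usual scatter of each other. Going from compound 2 to compound 1 the change is chloro in place of hydrogen on an aromatic carbon, and it made a step of a 9.8-fold lower number from compound 2 to compound 1 (0.99 log units; beyond the scatter). Compound 4 `ClCc1cccc(Cn2cnc3c(Cl)nc(Cl)nc32)c1` has not yet been measured; it differs from compound 3 by chloro in place of hydrogen on an aromatic carbon, the same change at the same place. Resting on the earlier step of a 9.8-fold lower number from compound 2 to compound 1 (0.99 log units; beyond the scatter), the expected step is a 9.5-fold lower number from compound 3 to compound 4 (0.98 log units; beyond the scatter). Compound 4 is accordingly estimated at 6500 nM, between 2500 nM and 17000 nM.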

Compound 4, concentration lethal to 50% of the cells: 40700 nM
Beside the measured number, compound 4's estimate is 6.3-fold (0.80 log units) below it; the measured number lies above the stated range.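

In this assay, chloro in place of hydrogen on an aromatic carbon gave a 1.5-fold lower number from compound 3 to compound 4 (0.18 log units; within the scatter), a step that stays within the scatter. The change therefore did not carry over in size from one core to the other: the same change on two cores in this assay, a 9.8-fold lower number (0.99 log units; beyond the scatter) from compound 2 to compound 1 and a 1.5-fold lower number (0.18 log units; within the scatter) from compound 3 to compound 4, 6.5-fold (0.81 log units) apart, beyond the scatter of two such steps. Among these compounds, this shows that the step made on one of these two cores was no guide to the step on the other, but two pairs cannot show what in the cores sets the gap, nor what the change would do on any further core.

The compounds shown leave open how an amine or a methoxy group would read on either core, set on the same aromatic carbon between two ring nitrogen atoms in place of the chloro.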